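A Ring Exchange With an Expected Outcome

The source may report more compounds than this note shows. Statements on the series, on what has been measured and on what is new or still open speak of the compounds shown alone.

Measured compounds:
compound 1, `COc1ccc(C(=O)/C(=C\c2ccc(O)c([N+](=O)[O-])c2)SCc2ccc(Br)cc2)cc1`, 10000 nM
compound 2, `Cc1ccc(S/C(=C/c2ccc(Cl)c(Cl)c2)C(=O)c2ccc(Br)cc2)cc1`, 50000 nM

Both compounds were tested in a functional assay on DU-145 cells (Homo sapiens) for inhibition, read by trypan blue exclusion, with a stated time of 96 h; a lower number here means a stronger inhibitor of growth, a higher number a weaker inhibitor of growth. Compound 1 gives 10000 nM in this assay, while compound 2 gives 50000 nM. Compound 2 therefore stands highest of the two numbers, and its nearest neighbour is compound 1, which lies beyond the scatter of this assay. Among the measured compounds shown here, no single-point step between the two measured compounds can be drawn, since they differ in more than one place.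

Compound 3, `Cc1ccc(S/C(=C/c2ccc(N(C)C)cc2)C(=O)c2ccc(Br)cc2)cc1`, has not yet been measured. It differs from compound 2 in one place: 4-(dimethylamino)phenyl in place of 3,4-dichlorophenyl on a double-bonded chain carbon bound to a double-bonded chain carbon. For the measured compounds named here, with no measured step of this kind available, the size of the change in this assay cannot be read from the two known values; a modest shift is expected, more likely toward a lower number than a higher one, but not with confidence beyond the scatter. The step from compound 2 to compound 3 is estimated as a 1.7-fold lower number from compound 2 to compound 3 (0.22 log units; within the scatter). Compound 3 is expected to give about 30000 nM in this assay, in the range 6000 nM to 100000 nM.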

Compound 3, concentration for 50% growth inhibition: > 100000 nM
Compound 3 gave a limit, no number; the forecaster's own chance of this, stated with the estimate: 20%; at least 3.3-fold (0.52 log units) between middle value and limit.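

Compound 3 gives no number in this assay, only a limit, > 100000 nM. Among the compounds shown here, the exchange of 3,4-dichlorophenyl for 4-(dimethylamino)phenyl on a double-bonded chain carbon bound to a double-bonded chain carbon is the first single change that can be followed, and it can be read only as a floor, an at least 2.0-fold higher number from compound 2 to compound 3 (0.30 log units; that floor lies within the scatter), so it gives no sign of a lower number, yet it does not by itself establish a gap beyond the scatter. This reading rests on a single compound at the edge of the measurable range: the limit of > 100000 nM in this assay, at which 1 of the 3 values shown sits.

Going by these compounds, how far the true value of compound 3 lies past its limit stays open, and with it the real size of this step. Also open, on these data alone, is whether a different group at this place, such as a primary amine or a carboxylic acid in place of the dimethylamino group, would give a number lower than that of compound 2 or would leave this assay's read-out unchanged.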